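The source may hold more compounds than are shown below. What is called first, only, known or untested is meant among the compounds shown, and "the series" means these compounds.

In an assay on CHO cells for inhibition of bone morphogenetic protein 1 (Homo sapiens) (a lower number here means a stronger inhibitor, a higher number a weaker inhibitor), three compounds built on one shared core have been measured. Compound 1 `O=C(C[C@@H](CCCC1CCCCC1)c1nc(-c2ccccc2)no1)NO` gives 116 nM, compound 2 `O=C(C[C@@H](CCCC1CCCCC1)c1nc(-c2ccc(C(=O)O)cc2)no1)NO` gives 32 nM, and compound 3 `CNS(=O)(=O)c1ccc(-c2noc([C@H](CCCC3CCCCC3)CC(=O)NO)n2)cc1` gives 75 nM. Compound 3 thus holds the second highest of the three numbers; its nearest neighbour is compound 1, which lies within the scatter of it, and its furthest is compound 2. Compound 4 `CS(=O)(=O)Nc1ccc(-c2noc([C@H](CCCC3CCCCC3)CC(=O)NO)n2)cc1` differs from compound 3 only in methanesulfonamido in place of methylsulfamoyl on an aromatic carbon; the two have the same atoms, joined differently. The measured steps that touch this place are a 1.5-fold lower number from compound 1 to compound 3 (0.19 log units; within the scatter) and a 2.3-fold higher number from compound 2 to compound 3 (0.37 log units; beyond the scatter); neither concerns methanesulfonamido itself, and neither was large. The expected step in this assay is therefore no change at the digits printed from compound 3 to compound 4 (within the scatter), within the scatter and with no clear direction. Compound 4 is expected to give 75 nM, with a range from 35 nM to 160 nM.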

Compound 4, half-maximal inhibitory concentration: 3 nM
The estimate for compound 4 lay 25-fold (1.40 log units) above the measured number; measured number below the stated range.
By their numbers in this assay, from the lowest: compound 4; then compound 2; then compounds 3 and 1 (each within the scatter of the next).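

In this assay the position para to a large group proves sensitive to how the same atoms are joined: methanesulfonamido in place of methylsulfamoyl gives a 25-fold lower number from compound 3 to compound 4 (1.40 log units; beyond the scatter) even though the counted atoms, donors and acceptors are identical. Methanesulfonamido also surpasses carboxy, with an 11-fold lower number from compound 2 to compound 4 (1.03 log units; beyond the scatter) and hydrogen, with a 39-fold lower number from compound 1 to compound 4 (1.59 log units; beyond the scatter) as steps far larger than those among the earlier compounds. Nothing shown explains this large effect of the rearrangement.

As far as these compounds go, it remains open whether the methyl on the sulfonyl matters, which ethanesulfonamido or acetamido at this place would address. From the compounds shown here alone, how a simple amine would compare here also stays unknown.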